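Chloro to Trifluoromethyl in a Small Cell-Growth Inhibitor Set

The source may hold more compounds than are shown below. What is called first, only, known or untested is meant among the compounds shown, and "the series" means these compounds.

Three compounds that share one core and differ only in the aryl group attached to it have been tested in a functional assay on MDA-MB-231 cells (Homo sapiens) for inhibition, read by MTT assay, with a stated time of 48 h; a lower number here means a stronger inhibitor, a higher number a weaker inhibitor. Compound 1 `CC1=C(CCc2nnn[nH]2)c2ccccc2/C1=C\c1cccc(Cl)c1` gives 24700 nM. Compound 2 `CC1=C(CCc2nnn[nH]2)c2ccccc2/C1=C\c1ccc(Cl)cc1` is built from the same atoms joined differently: 4-chlorophenyl in place of 3-chlorophenyl on a double-bonded chain carbon bound to a double-bonded ring carbon. In this assay compound 2 gives 15200 nM, a step of a 1.6-fold lower number from compound 1 to compound 2 (0.21 log units; within the scatter). Compound 3 `CC1=C(CCc2nnn[nH]2)c2ccccc2/C1=C\c1cccc(C(F)(F)F)c1` carries a different group on its aromatic ring: trifluoromethyl in place of chloro on an aromatic carbon. In this assay compound 3 gives 15600 nM, which amounts to a 1.6-fold lower number from compound 1 to compound 3 (0.20 log units; within the scatter). Neither step is large enough to count as a real change, so the three measured compounds sit close together.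

Compound 4 `CC1=C(CCc2nnn[nH]2)c2ccccc2/C1=C\c1ccc(C(F)(F)F)cc1` has not yet been measured. It relates to compound 2 as compound 3 relates to compound 1: trifluoromethyl in place of chloro on an aromatic carbon. The surroundings are not identical, since in compound 3 the new group sits meta to a large group while in compound 4 it sits para to a large group, so this is the same kind of change rather than the same change. Within the data shown here, the only guide is the measured step of a 1.6-fold lower number from compound 1 to compound 3 (0.20 log units; within the scatter), which stayed within the scatter. The expectation for compound 4 is a step of about a 1.3-fold lower number from compound 2 to compound 4 (0.10 log units; within the scatter), resting on that single earlier step and carrying the uncertainty that one example brings. Compound 4 is therefore estimated at 12000 nM in this assay, with a likely range from 6000 nM to 25000 nM.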

Compound 4, half-maximal inhibitory concentration: 22100 nM
For compound 4 the middle estimate is 1.8-fold (0.27 log units) below the measured one; the measured number falls inside the stated range.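

In this assay, trifluoromethyl in place of chloro gives a 1.5-fold higher number from compound 2 to compound 4 (0.16 log units; within the scatter), so on this core the change cannot be told apart from the ordinary spread of repeat measurements. This does not show that the change is without effect in general, because two small steps from a single assay are too few to support that, and it does not show that either core has a real preference for one group over the other. On paper the two steps run in opposite directions, but the gap between them is no larger than measurement scatter allows, so the series gives no sign that the two cores respond differently: the same change on two cores in this assay, a 1.6-fold lower number (0.20 log units; within the scatter) from compound 1 to compound 3 and a 1.5-fold higher number (0.16 log units; within the scatter) from compound 2 to compound 4, 2.3-fold (0.36 log units) apart, within the scatter of two such steps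

The compounds shown leave open whether a group of a different kind on the same aromatic ring, such as an amine, a carboxylic acid or a methoxy group, would move the number by more than the scatter. They also leave open whether a longer chain on the shared core would do so, and whether any of these results would hold in a different kind of cell.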